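The source may hold more compounds than are shown below. What is called first, only, known or untested is meant among the compounds shown, and "the series" means these compounds.

Compound 1 `CN(C)CCn1cnnc1-c1cc(Oc2ccc(NC(=O)N/N=C/c3c(Cl)cccc3Cl)cc2F)ccn1` stands at the edge of what a functional assay on U-87MG ATCC cells (Homo sapiens) for cytotoxicity, read by MTT assay, with a stated time of 72 h (on this read-out lower numbers stand for stronger inhibition and higher numbers for weaker inhibition), reports: in this assay compound 1 gives > 100000 nM, which is a limit and not a number (the limit of > 100000 nM in this assay, at which 1 of the 2 values shown sits). Compound 3 `CN(C)CCn1cnnc1-c1cc(Oc2ccc(NC(=O)N/N=C/c3ccc(O)cc3O)cc2F)ccn1` differs from it by 2,4-dihydroxyphenyl in place of 2,6-dichlorophenyl on a carbon with a double bond to nitrogen. For the measured compounds named here, the one measured step that bears on this change is the departure of the same 2,6-dichlorophenyl in compound 2 `CN(C)CCn1cnnc1-c1cc(Oc2ccc(NC(=O)N/N=C/c3cccc(Br)c3)cc2F)ccn1`, where in this assay compound 2 gives 830 nM, a step of an at least 120-fold lower number from compound 1 to compound 2 (2.08 log units; beyond the scatter). A large step in the same direction is therefore expected, an at least 40-fold lower number from compound 1 to compound 3 (1.60 log units; beyond the scatter). Compound 3 is estimated at 2500 nM, within 300 nM to 30000 nM.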

Compound 3, half-maximal inhibitory concentration: 15400 nM
Estimate against measurement, compound 3: 6.2-fold (0.79 log units) below; low and high end bracket the measured number.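

Within this assay the change to 2,4-dihydroxyphenyl gives an at least 6.4-fold lower number from compound 1 to compound 3 (0.81 log units; beyond the scatter) and thus shows that a lower number than the limit of compound 1 is not confined to 3-bromophenyl. Yet the two replacements at this carbon are far from equal, with a 19-fold higher number from compound 2 to compound 3 (1.27 log units; beyond the scatter) separating them. The value of compound 1 is a limit and not a number: the limit of > 100000 nM in this assay, at which 1 of the 3 values shown sits. As far as these compounds go, whether a single hydroxyl, a methoxy group or an amine on the phenyl ring would fall nearer compound 2 or compound 3 stays open. So does the question of whether chlorine in place of bromine would keep the value of compound 2.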